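A 3-bromophenyl in place of 2,4-dichlorophenyl

The source may report more compounds than this note shows. Statements on the series, on what has been measured and on what is new or still open speak of the compounds shown alone.

In a functional assay on aorta (Rattus norvegicus) for inhibition (a lower number here means a stronger inhibitor, a higher number a weaker inhibitor), compound 1 `O=C(Nc1cc2cc[nH]c(=O)c2cc1Cl)C1CNCCC1c1ccccc1` gives 55 nM. Compound 2 `O=C(Nc1cc2cc[nH]c(=O)c2cc1Cl)C1CNCC1c1ccc(Cl)cc1Cl` has no single number to stand on, its entry reading "not determined" (no result reported). Compound 3 `O=C(Nc1cc2cc[nH]c(=O)c2cc1Cl)C1CNCC1c1cccc(Br)c1` has not yet been measured. The change 3-bromophenyl in place of 2,4-dichlorophenyl on a saturated ring carbon puts 3-bromophenyl in place of 2,4-dichlorophenyl on a saturated ring carbon. For the measured compounds named here, no measured step exists to guide this change, so no step beyond the scatter is expected in this assay, and the only number to lean on is that of compound 1 at 55 nM. Compound 3 is expected at 90 nM, with an estimated range from 20 nM to 400 nM.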

Compound 3, half-maximal inhibitory concentration: 63 nM
For compound 3 the middle estimate is 1.4-fold (0.15 log units) above the measured one; measured number inside the range.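

No new step can be read between compound 2 and compound 3 in this assay. The compounds shown leave open how 3-bromophenyl and 2,4-dichlorophenyl compare on the shared core, and no evidence bears on this result.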